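A few compounds are considered here, and "the series" means these few. Any claim that something is new, unique, unknown or untested is made for them only; others in the source may bear on it.

Compound 1 `CC(=O)N1CCC(c2cc3c(-c4ccc(=O)n(C(C)C)c4)ccnc3[nH]2)CC1`: 2.1
Compound 2 `COc1cc(F)ccc1-c1ccnc2[nH]c(C3CCN(CC(=O)N(C)C)CC3)cc12`: 2.9

In a physicochemical assay for lipophilicity, using the shake flask method, measured as octanol-water partition, at pH 7.4 (on this read-out lower numbers stand for lower lipophilicity and higher numbers for higher lipophilicity), compound 2 stands higher of the two at 2.9, a gap to compound 1 that lies beyond the scatter. Compound 3 `CC(C)n1cc(-c2ccnc3[nH]c(C4CCN(CC(=O)N(C)C)CC4)cc23)cnc1=O` changes one place in compound 2: a group of 10 heavy atoms (7 carbon, 2 nitrogen, 1 oxygen; one six-membered aromatic ring with 2 hetero atoms) in place of a group of 9 heavy atoms (7 carbon, 1 oxygen, 1 fluorine; one six-membered aromatic ring of carbon only), on an aromatic carbon. Among the measured compounds shown here, no measured pair isolates this change. Compound 1 also lacks the 4-fluoro-2-methoxyphenyl group and carries a ring with a ring nitrogen there, though it differs elsewhere too, and it reads 2.1. A downward step beyond the scatter is therefore expected, a number 1.10 log units lower from compound 2 to compound 3 (beyond the scatter). The estimated value for compound 3 is 1.8, with an expected range of 1.2 to 2.4.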

Compound 3, distribution coefficient: 0.4
Compound 3: the middle estimate sits 1.40 log units above what was measured; measured number below the stated range.
By their numbers in this assay, from the lowest: compound 3; then compound 1; then compound 2.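

In this assay, replacing the 4-fluoro-2-methoxyphenyl group with a six-membered aromatic ring with 2 hetero atoms gives a number 2.50 log units lower from compound 2 to compound 3 (beyond the scatter). Among the compounds shown here, this is the first single-place comparison at this aromatic carbon, opposite the ring nitrogen, and it shows that the group held there can move this read-out a long way. No measurement shown here explains the size of the step. The compounds shown leave open which part of the new group carries the step, and where a simpler group such as unsubstituted phenyl or pyridine would fall. They also leave open whether the same swap on the core of compound 1 would give a similar step.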